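Aminophenyl to dichlorophenyl on the enone of a pyrazole series

The source may hold more compounds than are shown below. What is called first, only, known or untested is meant among the compounds shown, and "the series" means these compounds.

Measured so far:
compound 1 `COc1ccc(-c2cc(/C=C/C(=O)c3ccc(N)cc3)[nH]n2)cc1` — 10200 nM
compound 2 `COc1cc(-c2cc(/C=C/C(=O)c3ccc(N)cc3)[nH]n2)cc(OC)c1OC` — 7020 nM

In a functional assay on A549 cells (Homo sapiens) for inhibition, read by sulforhodamine B assay, with a stated time of 48 h (a higher number here means a weaker inhibitor of growth, a lower number a stronger inhibitor of growth), compound 2 gives 7020 nM, the lowest of the two numbers; compound 1 gives 10200 nM, which lies within the scatter of compound 2, so no order between them is claimed. Compound 3 `COc1cc(-c2cc(/C=C/C(=O)c3ccc(Cl)c(Cl)c3)[nH]n2)cc(OC)c1OC` is not yet measured. It differs from compound 2 by 3,4-dichlorophenyl in place of 4-aminophenyl on a carbonyl carbon. Within the data shown here, no measured pair gives a reading of this change, so only the size of the step is guessed: a small move toward a lower number, not clearly beyond the scatter, is expected for the step of a 1.4-fold lower number from compound 2 to compound 3 (0.15 log units; within the scatter). For compound 3 the estimate is 5000 nM, with a range from 1500 nM to 16000 nM.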

Compound 3, concentration for total growth inhibition: > 100000 nM
Compound 3: a limit, no number; the forecaster's own chance of this, stated with the estimate: 5%; middle value at least 20-fold (1.30 log units) from the limit.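

Placing 3,4-dichlorophenyl on the carbonyl carbon in place of 4-aminophenyl gives an at least 14-fold higher number from compound 2 to compound 3 (1.15 log units; beyond the scatter) in this assay. The reading for compound 3 is a limit of the assay, not a number: the limit of > 100000 nM in this assay, at which 1 of the 3 values shown sits. Among these compounds, compound 1 and compound 2 both carry 4-aminophenyl, so only this step shows that the group on the carbonyl carbon can matter strongly.

On these data alone, it remains open whether the step reflects the amine leaving or the two chlorines entering. A plain phenyl or a 4-chlorophenyl at this place would separate these two readings.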